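The compounds below may be only part of what the source reports. "The series", "measured", "known", "first", "only" and "open" are said of these compounds alone.

Measured compounds in a functional assay on HL-60 cells (Homo sapiens) for antiproliferative activity, read by MTT assay, with a stated time of 72 h; a lower number here means a stronger inhibitor, a higher number a weaker inhibitor:
Compound 1 `COc1cc(C(=O)c2sc3ccccc3c2-c2ccc(Cl)cc2)cc(OC)c1OC` gives 3300 nM.
Compound 2 `COc1cc(C(=O)c2sc3ccccc3c2-c2ccc(SC)cc2)cc(OC)c1OC` gives 1300 nM.
Compound 3 `COc1ccc(-c2c(C(=O)c3cc(OC)c(OC)c(OC)c3)sc3ccccc23)cc1C` reaches only the limit of this assay, > 10000 nM.

Among the three values shown, compound 3 sits at the weak end: it is the one value at the limit of > 10000 nM in this assay, at which 1 of the 3 values shown sits, and the steps of an at least 3.0-fold higher number from compound 1 to compound 3 (0.48 log units; beyond the scatter) and an at least 7.6-fold higher number from compound 2 to compound 3 (0.88 log units; beyond the scatter) are both beyond the scatter. Compounds 1 and 2 differ only by a 2.5-fold lower number from compound 1 to compound 2 (0.40 log units; beyond the scatter).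

Compound 4 `CCOc1ccc(Nc2c(C(=O)c3cc(OC)c(OC)c(OC)c3)sc3ccccc23)cc1` is not yet measured. It differs from compound 3 by (4-ethoxyphenyl)amino in place of 4-methoxy-3-methylphenyl on an aromatic carbon.

Going by the values given here, none of the measured steps changes this position in the same way: the two that bear on it, an at least 3.0-fold higher number from compound 1 to compound 3 (0.48 log units; beyond the scatter) and an at least 7.6-fold higher number from compound 2 to compound 3 (0.88 log units; beyond the scatter), exchange one aromatic ring for another, whereas compound 4 brings an amino-linked ring. They do show that the group at this position moves this assay by at least modest amounts, so a step beyond the scatter in either direction is plausible, and the starting point is a limit, which leaves the downward direction open.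

The number for compound 4 is expected to be 3000 nM, within 500 nM to 20000 nM, i.e. an estimated step of an at least 3.3-fold lower number from compound 3 to compound 4 (0.52 log units; beyond the scatter), with a real chance that only a limit is again reported.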

Compound 4, half-maximal inhibitory concentration: 500 nM
Beside the measured number, compound 4's estimate is 6.0-fold (0.78 log units) above it, and the stated range covers the measured number.
By their numbers in this assay, from the lowest: compound 4; then compound 2; then compound 1. At a limit, above all of these: compound 3.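

Compound 1, compound 2 and compound 3 all carry an aromatic ring directly on this carbon, and compound 4 shows that a (4-ethoxyphenyl)amino group can stand there with a lower number in this assay than either measured aryl compound: a 2.6-fold lower number from compound 2 to compound 4 (0.41 log units; beyond the scatter) and a 6.6-fold lower number from compound 1 to compound 4 (0.82 log units; beyond the scatter). Both steps are modest, so the amino-linked ring gives the lowest number of the four compounds shown without changing the scale of activity by much against the better aryl groups, while the step against the poorest aryl group is large, an at least 20-fold lower number from compound 3 to compound 4 (1.30 log units; beyond the scatter). That last step is a bound only, and compound 3 stands at a limit of the assay: the limit of > 10000 nM in this assay, at which 1 of the 4 values shown sits.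

Every step to compound 4 changes the ring substituent along with the link, so the share of the amino link and the share of the ethoxy group cannot be separated here. Also open, on these data alone, is how a (4-chlorophenyl)amino group, a methylamino link or an ether oxygen link would read in this assay.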